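Aryl amidrazone thiosemicarbazides: cytotoxicity notes toward compound 4

The source may hold more compounds than are shown below. What is called first, only, known or untested is meant among the compounds shown, and "the series" means these compounds.

Measured compounds in a functional assay on MCF7 cells (Homo sapiens) for cytotoxicity, read by MTT assay, with a stated time of 72 h, tested at 10 uM; on this read-out lower numbers stand for less inhibition of growth and higher numbers for more inhibition of growth at the one concentration tested:
Compound 1, `Cc1ccnc(/C(N)=N/NC(=S)N2CCCCCC2)c1`: 60.3%
Compound 2, `N/C(=N\NC(=S)N1CCOCC1)c1ccc(F)cn1`: 39.5%
Compound 3, `N/C(=N\NC(=S)N1CCN(c2ccccn2)CC1)c1ccc(F)cn1`: 35.8%

Compound 3 stands within the scatter of compound 2, so the two cannot be ordered, while it sits beyond the scatter below compound 1. Among the compounds with values here, no step between measured compounds that differ in a single place exists in this set, so every comparison across it mixes more than one change.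

Compound 4 is `Cc1ccnc(/C(N)=N/NC(=S)N2CCN(c3ccccn3)CC2)c1`. It differs from compound 3 in one place: 4-methylpyridin-2-yl in place of 5-fluoropyridin-2-yl on a carbon with a double bond to nitrogen. Compound 1 also carries the 4-methylpyridin-2-yl group and gives 60.3%, but its other end differs too, so that number is only a loose guide.

The expectation for compound 4 is a modest rise in this assay, with the step of a number 9.2 percentage points higher from compound 3 to compound 4 (within the scatter) possibly no larger than the scatter. Compound 4 is estimated at 45%, between 28% and 62%.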

Compound 4, percent growth inhibition at one concentration: 32.1%
The estimate for compound 4 lay 12.9 percentage points above the measured number, within the range that was stated.
By their numbers in this assay, from the lowest: compounds 4, 3 and 2 (each within the scatter of the next); then compound 1.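

In this assay, within the data shown here, the first step between compounds that differ in one place reads a number 3.7 percentage points lower from compound 3 to compound 4 (within the scatter), so 4-methylpyridin-2-yl and 5-fluoropyridin-2-yl on a carbon with a double bond to nitrogen cannot be told apart with this other end in place. The 4-methylpyridin-2-yl group therefore does not carry the higher number by itself: compound 1 gives 60.3%, while compound 4, with the same group and a different other end, gives 32.1%. Nothing at hand explains this result.

Open, as far as these compounds go, is whether 5-fluoropyridin-2-yl would also stay within the scatter of 4-methylpyridin-2-yl with the other end of compound 1. Also open, from the compounds shown here alone, is how a phenyl group or a carboxylic acid at this place would read in this assay.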